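Turning one double bond in a macrolide from Z to E

The source may hold more compounds than are shown below. What is called first, only, known or untested is meant among the compounds shown, and "the series" means these compounds.

Compound 1 `CC(=O)N[C@H](C)[C@@H](O)[C@@H](C)[C@@H]1OC(=O)CC/C=C(C)\C=C\[C@]2(C)CCC=C[C@@H]2/C=C(C)/C=C/[C@H]1C` and compound 2 `CC(=O)N[C@H](C)[C@@H](O)[C@@H](C)[C@@H]1OC(=O)/C=C/C=C(C)\C=C\[C@]2(C)CCC=C[C@@H]2/C=C(C)/C=C/[C@H]1C` share a large ring and the same side chain. In a functional assay on SF-295 cells (Homo sapiens) for antiproliferative activity, read by resazurin assay, with a stated time of 72 h (on this read-out lower numbers stand for stronger inhibition and higher numbers for weaker inhibition), compound 1 gives only a limit, > 5000 nM, so no number is known for it. Compound 2 gives 63.5 nM, the only numeric result in this assay. The other result on the table, that of compound 1, is the limit (the limit of > 5000 nM in this assay, at which 1 of the 2 values shown sits).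

Within the data shown here, compound 3 `CC(=O)N[C@H](C)[C@@H](O)[C@@H](C)[C@@H]1OC(=O)/C=C/C=C(C)/C=C/[C@]2(C)CCC=C[C@@H]2/C=C(C)/C=C/[C@H]1C` is the next case. the two compounds have the same atoms and bonds and differ only in configuration as drawn: 1 of 12 stereo elements differ; a double bond is drawn Z in compound 2 and E in compound 3 Nothing in the data measures what such a change in configuration does here, and no step between measured compounds is available for comparison. Compound 3 is therefore expected to land with a modest loss, an estimated step from compound 2 of a 3.1-fold higher number from compound 2 to compound 3 (0.50 log units; beyond the scatter), though a wide range must be allowed. In this assay compound 3 is estimated at 200 nM, expected between 40 nM and 2000 nM.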

Compound 3, half-maximal inhibitory concentration: 611 nM
Compound 3: the middle estimate sits 3.1-fold (0.49 log units) below what was measured; low and high end bracket the measured number.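

In this assay, changing a single double bond from Z to E gives a 9.6-fold higher number from compound 2 to compound 3 (0.98 log units; beyond the scatter). Among these compounds, this is the first step in the set that can be read as a number, and it shows that the drawn geometry of this one bond matters on its own, since nothing else in the structure changes: the fact that compounds 2 and 3 differ only in the configuration as drawn. The change weakens the result but does not abolish it, as compound 3 still gives a measured number rather than a limit.

As far as these compounds go, only this one double bond has been compared in its two forms, so it remains open whether the other double bonds in the large ring are equally sensitive. The side chain is also the same throughout, which leaves open whether this step would keep its size with an amine or a carboxylic acid in that chain.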